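From a Chloro Handle to a Heptylamino Chain

A few compounds are considered here, and "the series" means these few. Any claim that something is new, unique, unknown or untested is made for them only; others in the source may bear on it.

Compound 3 `O=C(NCc1ccccc1)c1nccnc1Cl` carries a chloro group on its core, while the two compounds measured alongside it each carry an alkylamino chain in that place. Compound 1 `CCCCCNc1cnc(C(=O)NCc2ccccc2)cn1` and compound 2 `CCCCCCCCNc1nccnc1C(=O)NCc1ccccc1` were tested in an ADME assay on HEL cells (Homo sapiens) for cytotoxicity, read by microscopy, with a stated time of 6 days; a higher number here means that more compound is tolerated, a lower number that less compound is tolerated. For compound 1 the value in this assay is a limit, > 100000 nM. For compound 2 the value is likewise a limit, > 100000 nM. For compound 3 no number exists at all: this assay reports "not determined" (no result reported). Where compound 3 stands can therefore be read only from its neighbours, and both of them sit at the limit of > 100000 nM in this assay, at which 2 of the 3 values shown sit.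

Compound 4 `CCCCCCCNc1nccnc1C(=O)NCc1ccccc1` is compound 3 with heptylamino in place of chloro on an aromatic carbon. Among the compounds with values here, no step between measured compounds is available, so the size of this particular step cannot be given; the two neighbours suggest no step beyond the scatter, since they both return a limit. For compound 4 the expected value in this assay is 100000 nM, with a range from 30000 nM to 300000 nM, and the likeliest outcome is expected to be another limit rather than a number.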

Compound 4, minimum cytotoxic concentration: 100000 nM
The estimate for compound 4 equals the measured number at the digits printed; the range from low to high includes it.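

In this assay, within the data shown here, compound 4 gives a plain number, 100000 nM, so a heptylamino chain on an aromatic carbon next to the ring nitrogen yields the first actual reading at this place. Shortening the chain by one carbon gives a number no higher from compound 2 to compound 4 (the limit leaves the size open), which fixes the direction of the step but not its size. The two alkylamino neighbours of compound 4 still stand at a limit and not at a number: the limit of > 100000 nM in this assay, at which 2 of the 4 values shown sit.

With no value for compound 3, the step from chloro to heptylamino cannot be read. From the compounds shown here alone, how a longer chain, a chain ending in a carboxylic acid or a cyclic amine at this place would fare in this assay remains open.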